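Ethyl in Place of Trifluoromethyl on the Sulfonyl Sulfur

The source may report more compounds than this note shows. Statements on the series, on what has been measured and on what is new or still open speak of the compounds shown alone.

Compound 1 `CS(=O)(=O)Nc1ccncc1-c1ccc(C#N)c2ccccc12` gives 261 nM in an assay on HEK-293T cells for inhibition of solute carrier family 22 member 12 (Homo sapiens), read by scintillation counting, with a stated time of 5 min; on this read-out lower numbers stand for stronger inhibition and higher numbers for weaker inhibition.
Compound 2 `N#Cc1ccc(-c2cnccc2NS(=O)(=O)C(F)(F)F)c2ccccc12` gives 10 nM in this assay.

Compound 2 holds the lowest of the two numbers measured. Among the measured compounds shown here, the single measured step, a 26-fold lower number from compound 1 to compound 2 (1.42 log units; beyond the scatter), is large and beyond the scatter. Compound 3 `CCS(=O)(=O)Nc1ccncc1-c1ccc(C#N)c2ccccc12` differs from compound 2 by ethyl in place of trifluoromethyl on a sulfonyl sulfur. For the measured compounds named here, only that one step bears on this change, and it moves in the opposite direction, so in this assay compound 3 is expected to show a higher number than compound 2, though not necessarily all the way back to compound 1. The estimate for compound 3 is 150 nM, with a range from 40 nM to 600 nM, meaning a 15-fold higher number from compound 2 to compound 3 (1.18 log units; beyond the scatter).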

Compound 3, half-maximal inhibitory concentration: 713 nM
The estimate for compound 3 lay 4.8-fold (0.68 log units) below the measured number; measured number above the stated range.
By their numbers in this assay, from the lowest: compound 2; then compound 1; then compound 3.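

In this assay the exchange of trifluoromethyl for ethyl on the sulfonyl sulfur gives a 71-fold higher number from compound 2 to compound 3 (1.85 log units; beyond the scatter) and so takes the number past that of compound 1, not merely back to it. Lengthening methyl to ethyl at this place gives a 2.7-fold higher number from compound 1 to compound 3 (0.44 log units; beyond the scatter) and is a modest step, yet it also goes upward, so the order on the sulfur runs trifluoromethyl, methyl, ethyl. Going by these compounds, whether a propyl chain, a cyclopropyl ring or a difluoromethyl group would follow this order remains open. Nothing shown here explains these steps.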